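Swapping Chloro for Bromo: What One Step Suggests

This account rests on a few compounds, and the source may have more. Where it says the series, first, only, none or still open, it means among the compounds named here.

In a functional assay on CCRF-CEM cells (Homo sapiens) for inhibition (on this read-out higher numbers stand for weaker inhibition and lower numbers for stronger inhibition), compound 1 `O=C1CCCCC/C1=C\c1ccc(F)cc1` gives 198000 nM, while compound 2 `O=C1CCCCC/C1=C\c1ccc(Cl)cc1` gives 43500 nM. Compound 2 therefore holds the lower number of the two and is the stronger inhibitor so far. The next compound, compound 3 `O=C1CCCCC/C1=C\c1ccc(Br)cc1`, keeps the shared core and has bromo in place of chloro on an aromatic carbon. Among the measured compounds shown here, only one measured step bears on this change. It is a 4.6-fold lower number from compound 1 to compound 2 (0.66 log units; beyond the scatter), a modest step beyond the usual scatter, made by putting chloro in place of fluoro on an aromatic carbon. A single step cannot establish a trend, so only a cautious extension seems reasonable. The expected change in this assay is a 1.5-fold lower number from compound 2 to compound 3 (0.16 log units; within the scatter), a smaller step in the same direction that may not clear the scatter. For compound 3, the estimated value is 30000 nM, with an expected range of 12000 nM to 80000 nM.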

Compound 3, half-maximal inhibitory concentration: 42800 nM
Compound 3: the middle estimate sits 1.4-fold (0.15 log units) below what was measured; the measured number falls inside the stated range.
By their numbers in this assay, from the lowest: compounds 3 and 2 (each within the scatter of the next); then compound 1.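

In this assay, bromo in place of chloro on this aromatic carbon gives a 1.0-fold lower number from compound 2 to compound 3 (0.01 log units; within the scatter) and stays within the scatter, so the two halogens cannot be told apart at this position. Fluoro is the group that stands apart so far: bromo in its place gives a 4.6-fold lower number from compound 1 to compound 3 (0.67 log units; beyond the scatter) and lies beyond the scatter, much like the earlier change from fluoro to chloro, so the series does not keep moving with each halogen beyond chloro. No measurement shown here explains why fluoro differs from the other two halogens. Going by these compounds, it remains open whether this position can hold something other than a halogen, such as an amine, a carboxylic acid or a longer chain. On these data alone, it also remains open whether a group larger than bromo would shift the number at all.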